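A few compounds are considered here, and "the series" means these few. Any claim that something is new, unique, unknown or untested is made for them only; others in the source may bear on it.

In a functional assay on QGY-7703 cells (Homo sapiens) for cytotoxicity, read by MTT assay, with a stated time of 24 h (a higher number here means a weaker inhibitor, a lower number a stronger inhibitor), the measured compounds are:
- compound 1 `Cc1ccc(S(=O)(=O)N2C/C(=C\c3cccnc3)C(=O)/C(=C/c3ccccc3F)C2)cc1` at 9700 nM
- compound 2 `O=C1/C(=C/c2ccncc2)CNC/C1=C\c1ccccc1F` at 14200 nM

Compound 2 stands within the scatter of compound 1 , so these two numbers cannot be told apart. The next step leads to compound 3 `Cc1ccc(S(=O)(=O)N2C/C(=C\c3ccncc3)C(=O)/C(=C/c3ccccc3F)C2)cc1` and places (4-methylphenyl)sulfonyl in place of hydrogen on an amine nitrogen in a ring. The counted change is (4-methylphenyl)sulfonyl in place of hydrogen on an amine nitrogen in a ring on that nitrogen. Within the data shown here, no measured pair differing in one place shows the size of such a change in this assay directly. Among the measured compounds shown here, the only guide is compound 1 , which also carries this group and gives 9700 nM within the scatter of the number for compound 2. No shift beyond the scatter is therefore expected, and the estimated 1.5-fold lower number from compound 2 to compound 3 (0.17 log units; within the scatter) stays small. The expected value for compound 3 is 9500 nM with an estimated range from 4000 nM to 22000 nM for this measurement.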

Compound 3, half-maximal inhibitory concentration: > 20000 nM
Compound 3: no number, only a limit; the forecaster's own chance of this, stated with the estimate: 3%; middle value at least 2.1-fold (0.32 log units) away from the limit.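

In this assay compound 3 gives a limit and not a number: the limit of > 20000 nM in this assay, at which 1 of the 3 values shown sits.
Pyridin-4-yl in place of pyridin-3-yl on the double-bonded chain carbon, with the (4-methylphenyl)sulfonyl group kept on the ring nitrogen, gives the first one-place reading in this series, an at least 2.0-fold higher number from compound 1 to compound 3 (0.31 log units; beyond the scatter), and this lies beyond the scatter. For (4-methylphenyl)sulfonyl in place of hydrogen on the amine nitrogen in the ring, the result is an at least 1.4-fold higher number from compound 2 to compound 3 (0.14 log units; that floor lies within the scatter), a floor within the scatter, so this change has no readable size yet.

The limit leaves the full size of both steps open. Also open, going by these compounds, is how a plain phenyl in place of the pyridine ring, or an acetyl or methanesulfonyl group on the ring nitrogen, would compare in this assay.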